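A few compounds are considered here, and "the series" means these few. Any claim that something is new, unique, unknown or untested is made for them only; others in the source may bear on it.

Measured in an ADME assay on the whole organism (Mus musculus, strain CD1) for pharmacokinetics, read by LC-MS, using cassette dosing, with a stated time of 24 h, at a dose of 0.4 mg/kg by the intravenous route; on this read-out higher numbers stand for fast clearance and lower numbers for slow clearance:
- compound 1 `Cc1cn(-c2cc(NC(=O)c3ccc(C)c(Nc4nccc(-c5ccccc5)n4)c3)cc(N3CCN(C)CC3)c2)cn1` gives 32.8 mL/min/kg
- compound 2 `Cc1cn(-c2cc(CN3CCC[C@H](N)C3)cc(NC(=O)c3ccc(C)c(Nc4nccc(-c5ccc(F)cc5)n4)c3)c2)cn1` gives 23.5 mL/min/kg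
- compound 3 `Cc1cn(-c2cc(NC(=O)c3ccc(C)c(Oc4ccccc4)c3)cc(N3CCN(C)CC3)c2)cn1` gives 17.5 mL/min/kg

All three numbers lie within the usual scatter of one another, so in this assay compound 3 cannot be set apart from compound 1 or compound 2; its number simply sits together with theirs.

Compound 4 `Cc1cn(-c2cc(NC(=O)c3ccc(C)c(C(=O)c4cccc(C#N)c4)c3)cc(N3CCN(C)CC3)c2)cn1` differs from compound 3 in one place: (3-cyanophenyl)carbonyl in place of phenoxy on an aromatic carbon. For the measured compounds named here, no measured pair of compounds shows what such an exchange does in this assay, so there is no step to lean on. With nothing beyond the scatter seen across the three measured compounds, the step from compound 3 to compound 4 is expected to be small, a 1.1-fold higher number from compound 3 to compound 4 (0.06 log units; within the scatter), in no particular direction. Compound 4 is therefore estimated at 20 mL/min/kg, within 10 mL/min/kg to 40 mL/min/kg.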

Compound 4, clearance: 81 mL/min/kg
Estimate against measurement, compound 4: 4.1-fold (0.61 log units) below; measured number above the stated range.
By their numbers in this assay, from the lowest: compounds 3, 2 and 1 (each within the scatter of the next); then compound 4.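

In this assay the exchange of phenoxy for (3-cyanophenyl)carbonyl gives a 4.6-fold higher number from compound 3 to compound 4 (0.67 log units; beyond the scatter) and so separates compound 4 from compound 3. For the compounds shown here, this aromatic carbon, ortho to a methyl group, is therefore a place where a single change can move clearance, which the earlier compounds, with no pair differing in one place, could not show. Nothing measured here explains the rise.

The exchange alters both the link to the ring and the ring's nitrile at once. Plain phenylcarbonyl or 3-cyanophenoxy at this position would be needed to tell those two apart.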